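A new aromatic ring on compound 2

This account rests on a few compounds, and the source may have more. Where it says the series, first, only, none or still open, it means among the compounds named here.

In an ADME assay on microsomes from liver (Homo sapiens) for metabolic stability (on this read-out lower numbers stand for slow clearance and higher numbers for fast clearance), compound 1 `CCn1cnc2c(-c3ccnc(Oc4ccccc4)c3)cnnc21` gives 51 mL.min-1.g-1. Compound 2 `CC(=O)N1CC(Oc2cc(-c3cnnc4c3ncn4C(C)C)ccc2F)C1` gives < 8 mL.min-1.g-1, and this is a limit of the assay, not a number. Compound 3 `Cc1cc(-c2cc(-c3cnnc4c3ncn4C(C)C)ccc2F)ccn1` carries 2-methylpyridin-4-yl in place of (1-acetylazetidin-3-yl)oxy on an aromatic carbon. Compound 1 also lacks the (1-acetylazetidin-3-yl)oxy group and stands at 51 mL.min-1.g-1, so faster clearance is expected here. The estimated change in this assay is an upward one, an at least 2.5-fold higher number from compound 2 to compound 3 (0.39 log units; beyond the scatter). For compound 3 the expected intrinsic clearance is 20 mL.min-1.g-1, with an estimated range of 9 mL.min-1.g-1 to 45 mL.min-1.g-1.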

Compound 3, intrinsic clearance in microsomes in the Homo sapiens assay: 102 mL.min-1.g-1
The estimate for compound 3 lay 5.1-fold (0.71 log units) below the measured number; measured number above the stated range.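

Swapping (1-acetylazetidin-3-yl)oxy for 2-methylpyridin-4-yl, ortho to a fluoro group, gives in the Homo sapiens assay an at least 12-fold higher number from compound 2 to compound 3 (1.10 log units; beyond the scatter), so clearance at this position responds strongly to the group placed there. From the compounds shown here alone, compound 2 stands at a limit of the assay, so the true size of this step stays unknown: the limit of < 8 mL.min-1.g-1 in the Homo sapiens assay, at which 1 of the 3 values shown sits. In a physicochemical assay for lipophilicity (a higher number here means a more lipophilic compound, a lower number a more polar compound), compound 2 gives 1.6 and compound 3 gives 3.1, so the faster clearance comes with a more lipophilic compound: the measured distribution coefficient of compound 2, 1.6, and of compound 3, 3.1, a number 1.50 log units higher (beyond the scatter). Going by these compounds, whether clearance follows the new aromatic ring itself or the lipophilicity stays open, as does what a morpholine or an unmethylated pyridine would do here.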